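Removing the acyl group from compound 3: an expected loss

The compounds below may be only part of what the source reports. "The series", "measured", "known", "first", "only" and "open" are said of these compounds alone.

Measured compounds:
Compound 1, `COc1ccc(CNc2cc(OC)c(OC)c(OC)c2)cc1C`, gives 73800 nM.
Compound 2, `COC(=O)c1cc(CNc2cc(OC)c(OC)c(OC)c2)ccc1OC`, gives 41100 nM.
Compound 3, `C/C=C/C(=O)N(Cc1ccc(OC)c(Cl)c1)c1cc(OC)c(OC)c(OC)c1`, gives 10100 nM.

These three compounds share a core and were tested in a functional assay on KYSE-450 cells (Homo sapiens) for inhibition, read by MTT assay, with a stated time of 48 h; a lower number here means a stronger inhibitor, a higher number a weaker inhibitor. Compound 3 has the lowest number of the three, and its gap to compound 2 and to compound 1 is in each case beyond the scatter. Compound 4, `COc1ccc(CNc2cc(OC)c(OC)c(OC)c2)cc1Cl`, is not yet measured. It differs from compound 3 in one place: hydrogen in place of (prop-1-en-1-yl)carbonyl on a nitrogen on an aromatic ring. Among the measured compounds shown here, the only step measured so far, a 1.8-fold lower number from compound 1 to compound 2 (0.25 log units; within the scatter), concerns a substituent on an aromatic carbon, not the nitrogen, so no measured step speaks directly to this change. What can be said is that compound 1 and compound 2, which both carry hydrogen on that nitrogen, give far higher numbers than compound 3. Compound 4 is therefore expected to move in the same direction, with the step of a 4.5-fold higher number from compound 3 to compound 4 (0.65 log units; beyond the scatter). For compound 4 the estimated value is 45000 nM, with a range from 15000 nM to 130000 nM.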

Compound 4, half-maximal inhibitory concentration: 47800 nM
Compound 4: the middle estimate sits 1.1-fold (0.03 log units) below what was measured; the range from low to high includes it.
By their numbers in this assay, from the lowest: compound 3; then compounds 2, 4 and 1 (each within the scatter of the next).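

Among the compounds shown here, replacing (prop-1-en-1-yl)carbonyl with hydrogen on this nitrogen gives a 4.7-fold higher number from compound 3 to compound 4 (0.68 log units; beyond the scatter), the first direct measurement of this change, with the rest of the molecule the same on both sides. Among the compounds with hydrogen on that nitrogen, the aromatic substituent matters little: chloro in place of methoxycarbonyl gives a 1.2-fold higher number from compound 2 to compound 4 (0.07 log units; within the scatter), and chloro in place of methyl gives a 1.5-fold lower number from compound 1 to compound 4 (0.19 log units; within the scatter). So among these four compounds, the acyl group on the nitrogen is the only change seen to move the number beyond the scatter.

No measurement shown gives a reason for this step. An acetyl group or a saturated butanoyl group on that nitrogen would test whether the lower number goes with the carbonyl alone or also needs the double bond.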